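The source may hold more compounds than are shown below. What is called first, only, known or untested is meant among the compounds shown, and "the series" means these compounds.

Three compounds have been measured in a functional assay on HL-60 cells (Homo sapiens) for antiproliferative activity, read by XTT assay, with a stated time of 72 h; a higher number here means a weaker inhibitor, a lower number a stronger inhibitor:

- compound 1, `COc1ncnc2c1c(-c1ccsc1)cn2[C@@H]1O[C@H](CO)[C@@H](O)[C@H]1O`, gives 130 nM
- compound 2, `COc1nc(N)nc2c1c(-c1ccsc1)cn2[C@@H]1O[C@H](CO)[C@@H](O)[C@H]1O`, reaches only a limit of this assay, > 20000 nM
- compound 3, `COc1ncnc2c1c(-c1cccs1)cn2[C@@H]1O[C@H](CO)[C@@H](O)[C@H]1O`, gives 80 nM

Compound 1 and compound 3 share one core and differ only in the thiophene attachment, (thiophen-2-yl in place of thiophen-3-yl on an aromatic carbon). The step is a 1.6-fold lower number from compound 1 to compound 3 (0.21 log units; within the scatter), so the two are not separated in this assay.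

Compound 1 and compound 2 differ by amino in place of hydrogen on an aromatic carbon. That step is an at least 150-fold higher number from compound 1 to compound 2 (2.18 log units; beyond the scatter); the value of compound 2 is a limit, (the limit of > 20000 nM in this assay, at which 1 of the 3 values shown sits), so the true size of the loss is not known beyond its lower bound.

Compound 4, `COc1nc(N)nc2c1c(-c1cccs1)cn2[C@@H]1O[C@H](CO)[C@@H](O)[C@H]1O`, is not yet measured. It differs from compound 3 by amino in place of hydrogen on an aromatic carbon. The place of the change is described in the same words as for the change from compound 1 to compound 2, so this is the same change made on the core that carries thiophen-2-yl instead of thiophen-3-yl. Going by the values given here, since the starting points compound 1 and compound 3 sit within the scatter of each other, and the only precedent for adding the amino group is the large loss to a limit, compound 4 is expected to lose activity to a similar degree, a 500-fold higher number from compound 3 to compound 4 (2.70 log units; beyond the scatter), and the assay is most likely to return only a limit again. The estimate for compound 4 in this assay is 40000 nM, expected between 8000 nM and 200000 nM.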

Compound 4, half-maximal inhibitory concentration: > 20000 nM
Compound 4 gave a limit, no number (the forecaster's own chance of this, stated with the estimate: 85%); the middle value is on the limit's open side.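

In this assay compound 4 gives only a limit, > 20000 nM, and not a number. Amino in place of hydrogen on the aromatic carbon between two ring nitrogen atoms therefore gives a large loss with thiophen-2-yl as well as with thiophen-3-yl on the core, with an at least 250-fold higher number from compound 3 to compound 4 (2.39 log units; beyond the scatter), and the two pairs compare as follows: the same change on two cores in this assay, an at least 150-fold higher number (2.18 log units; beyond the scatter) from compound 1 to compound 2 and an at least 250-fold higher number (2.39 log units; beyond the scatter) from compound 3 to compound 4; the limit leaves it open whether they differ. This shows that the loss carries over between these two closely related cores, but each step is only a lower bound, so it does not show that the loss is equal in size on both, and the step between compound 2 and compound 4 cannot be read; two pairs also make no rule for cores carrying other groups.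

From the compounds shown here alone, it remains open whether the loss is specific to amino or would also follow from another group on the same aromatic carbon, such as methyl, chlorine or methylamino. Going by these compounds, it is also open whether amino is tolerated when the methoxy group gives way to an ethoxy group or a dimethylamino group, or when a furan-2-yl group takes the place of the thiophene.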